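Bromo in Place of Fluoro: From Compound 3 to Compound 4

The source may hold more compounds than are shown below. What is called first, only, known or untested is meant among the compounds shown, and "the series" means these compounds.

Three compounds built on one shared core were examined in an assay on Sf21 cells for inhibition of ubiquitin carboxyl-terminal hydrolase 7 (Homo sapiens), read by spectrophotometry, with stated times of 30 min and 2 h; on this read-out lower numbers stand for stronger inhibition and higher numbers for weaker inhibition. In this assay compound 1 `O=c1c2cnn(-c3ccc(F)cc3)c2ncn1CC1(O)CCN(Cc2cccc(Cl)c2)CC1` is reported as "not determined" (no result reported), and compound 2 `O=c1c2cnn(-c3ccc(F)cc3)c2ncn1CC1(O)CCN(Cc2ccc(C(F)(F)F)cc2)CC1` is likewise reported as "not determined" (no result reported). Among the compounds with values here, compound 3 `O=c1c2cnn(-c3ccc(F)cc3)c2ncn1CC1(O)CCN(Cc2ccc(F)cc2Cl)CC1` is the only one with a number: in this assay compound 3 gives 1600 nM, so it stands alone, with nothing measured to rank it against. Compound 4 `O=c1c2cnn(-c3ccc(F)cc3)c2ncn1CC1(O)CCN(Cc2ccc(Br)cc2Cl)CC1` differs from compound 3 in one place: bromo in place of fluoro on an aromatic carbon. Within the data shown here, no step between two measured compounds is available to guide this change, so the expectation rests on the single value of compound 3. The step of a 1.6-fold lower number from compound 3 to compound 4 (0.20 log units; within the scatter) is expected to stay near the scatter, with a lean toward slightly stronger inhibition. Compound 4 is therefore estimated at 1000 nM in this assay, within a range from 400 nM to 3000 nM.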

Compound 4, half-maximal inhibitory concentration: 1900 nM
Beside the measured number, compound 4's estimate is 1.9-fold (0.28 log units) below it; measured number inside the range.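

In this assay, within the data shown here, the change shows a 1.2-fold higher number from compound 3 to compound 4 (0.07 log units; within the scatter), the first reading at this position on the ring: the 2-chloro-4-fluorobenzyl and 4-bromo-2-chlorobenzyl groups cannot be told apart. Here, one halogen in place of another, with the chloro group kept, leaves the two compounds level. Nothing available bears on why this is so. The compounds shown leave open whether an amine, a carboxylic acid or a methoxy group at this same position would separate from these halogens. They also leave open what the value would be without the chloro group.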